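Two nitriles replace the dimethoxyethyl amide of compound 3

The source may hold more compounds than are shown below. What is called first, only, known or untested is meant among the compounds shown, and "the series" means these compounds.

Measured compounds:
compound 1, `CCn1c(C(=O)NCCCN(C)C)ccc1C(CC)(CC)c1ccc(OCC(O)C(C)(C)C)c(C)c1`: 197 nM
compound 2, `CCN(CC)CCCNC(=O)c1ccc(C(CC)(CC)c2ccc(OCC(O)C(C)(C)C)c(C)c2)n1CC`: 71.1 nM
compound 3, `CCn1c(C(=O)NCC(OC)OC)ccc1C(CC)(CC)c1ccc(OCC(O)C(C)(C)C)c(C)c1`: 5240 nM

In an assay on isolated protein for binding affinity to vitamin D3 receptor (Homo sapiens), with a stated time of 4 h (on this read-out lower numbers stand for stronger inhibition and higher numbers for weaker inhibition), compound 3 stands with the highest number of the three, with compound 1 nearest and compound 2 furthest. Compound 4, `CCn1c(C(=O)N(CCC#N)CCC#N)ccc1C(CC)(CC)c1ccc(OCC(O)C(C)(C)C)c(C)c1`, differs from compound 3 in one place: a group of 9 heavy atoms (6 carbon, 3 nitrogen; no ring) in place of a group of 7 heavy atoms (4 carbon, 1 nitrogen, 2 oxygen; no ring), on a carbonyl carbon. For the measured compounds named here, no measured step covers this exchange itself. The steps that come closest concern the same amide substituent: a 27-fold higher number from compound 1 to compound 3 (1.42 log units; beyond the scatter) and a 74-fold higher number from compound 2 to compound 3 (1.87 log units; beyond the scatter). Both show that the (2,2-dimethoxyethyl)amino group of compound 3 sits far from the two amides with a lower number, yet the group that enters in compound 4 resembles neither the 2-(dimethylamino)ethyl of compound 1 nor the 2-(diethylamino)ethyl of compound 2. On this evidence compound 4 is expected to stay near compound 3, with a step of a 1.2-fold higher number from compound 3 to compound 4 (0.09 log units; within the scatter) that need not go beyond the scatter, and a slight drift to a higher number is as plausible as a gain. Compound 4 is therefore estimated at 6500 nM, within 1500 nM to 28000 nM.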

Compound 4, half-maximal inhibitory concentration: > 10000 nM
Compound 4 gave a limit, no number; the forecaster's own chance of this, stated with the estimate: 15%; at least 1.5-fold (0.18 log units) between middle value and limit.
By their numbers in this assay, from the lowest: compound 2; then compound 1; then compound 3. At a limit, above all of these: compound 4.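

The reading of compound 4 in this assay rests on a limit, not a number: the limit of > 10000 nM in this assay, at which 1 of the 4 values shown sits. Its step, an at least 1.9-fold higher number from compound 3 to compound 4 (0.28 log units; that floor lies within the scatter), has a floor within the usual scatter, so this exchange on the carbonyl carbon is not shown to lower binding beyond the level already seen with the (2,2-dimethoxyethyl)amino group. The steps of an at least 140-fold higher number from compound 2 to compound 4 (2.14 log units; beyond the scatter) and an at least 50-fold higher number from compound 1 to compound 4 (1.70 log units; beyond the scatter) are both large, so a second amide substituent without a dialkylamino end, this one with two nitriles and no hydrogen-bond donor, also stays far from the two amides with the lowest numbers.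

Compound 4 loses the amide hydrogen and the earlier chain together, and the compounds shown do not separate these two changes. Going by these compounds, how a single nitrile chain on a secondary amide, a pyrrolidine end or a carboxylic acid end would read stays open.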